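Replacing the 3-methoxyphenyl group of compound 2

The source may report more compounds than this note shows. Statements on the series, on what has been measured and on what is new or still open speak of the compounds shown alone.

In a functional assay on Huh-7 cells (Homo sapiens) for inhibition, read by MTT assay, with a stated time of 48 h (a lower number here means a stronger inhibitor, a higher number a weaker inhibitor), compound 1 `COc1ccc2c(=O)c(/C=C/C(=O)Nc3cccc(C)c3)coc2c1` gives 15500 nM and compound 2 `COc1cccc(NC(=O)/C=C/c2coc3cc(OC)ccc3c2=O)c1` gives 11100 nM, so the two stand level within the scatter. Compound 3 `COc1ccc2c(=O)c(/C=C/C(=O)NCc3ccc(F)cc3)coc2c1` differs from compound 2 (4-fluorobenzyl in place of 3-methoxyphenyl on an amide-type nitrogen), with 4-fluorobenzyl in place of 3-methoxyphenyl on an amide-type nitrogen. Going by the values given here, the only measured step, a 1.4-fold lower number from compound 1 to compound 2 (0.15 log units; within the scatter), is methoxy in place of methyl on an aromatic carbon, and it leaves that nitrogen untouched. It therefore offers weak guidance, and no change beyond the scatter is expected in this assay. The expected step is a 1.2-fold higher number from compound 2 to compound 3 (0.07 log units; within the scatter). The estimate for compound 3 is 13000 nM, with an expected range of 5500 nM to 32000 nM.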

Compound 3, half-maximal inhibitory concentration: 21000 nM
Estimate against measurement, compound 3: 1.6-fold (0.21 log units) below; the range from low to high includes it.
By their numbers in this assay, from the lowest: compounds 2, 1 and 3 (each within the scatter of the next).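

In this assay the amide-type nitrogen, left untouched by the earlier step, now carries a different group: 4-fluorobenzyl in place of 3-methoxyphenyl gives a 1.9-fold higher number from compound 2 to compound 3 (0.28 log units; within the scatter) and 4-fluorobenzyl in place of 3-methylphenyl gives a 1.4-fold higher number from compound 1 to compound 3 (0.13 log units; within the scatter) on the same nitrogen. On this nitrogen, then, 4-fluorobenzyl stands level with both groups it replaces. No evidence at hand accounts for this result. From the compounds shown here alone, whether an amine, a carboxylic acid or a longer chain on this nitrogen would move the number beyond the scatter remains open.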